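Swapping sulfamoyl for methylsulfonyl in a pyrimidine diamine series

The compounds below may be only part of what the source reports. "The series", "measured", "known", "first", "only" and "open" are said of these compounds alone.

Of the compounds shown here, three have been measured in a functional assay on MDA-MB-231 cells (Homo sapiens) for antiproliferative activity, read by MTT assay, with a stated time of 48 h; a lower number here means a stronger inhibitor, a higher number a weaker inhibitor. Compound 1 `COc1ccc2nc(Nc3ccnc(Nc4ccc(S(N)(=O)=O)cc4)n3)sc2c1` gives 6240 nM. Compound 3 `Cc1ccc2nc(Nc3ccnc(Nc4ccc(S(C)(=O)=O)cc4)n3)sc2c1` gives 4440 nM. Compound 2 `NS(=O)(=O)c1ccc(Nc2ncc(F)c(Nc3nc4ccccc4s3)n2)cc1` gives 22600 nM, the highest of the three numbers; its gap to compound 1 and to compound 3 lies beyond the scatter in both cases, so compound 2 is the weakest inhibitor of the set.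

The step now under consideration leads from compound 2 to compound 4 `CS(=O)(=O)c1ccc(Nc2ncc(F)c(Nc3nc4ccccc4s3)n2)cc1`. The change is methyl in place of amino on a sulfonyl sulfur. Among the compounds with values here, no pair of measured compounds differs in this one place alone, so the size of such a step is not known from direct comparison. Compound 1 carries sulfamoyl and compound 3 carries methylsulfonyl, but they also differ elsewhere, and their two values lie within the scatter of each other.

On this basis the step is expected to be small in this assay. Compound 4 is expected to give 15000 nM, within 5000 nM to 45000 nM. The expected step of a 1.5-fold lower number from compound 2 to compound 4 (0.18 log units; within the scatter) would stay near the scatter, pointing, if anywhere, toward a lower number.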

Compound 4, half-maximal inhibitory concentration: 4980 nM
Beside the measured number, compound 4's estimate is 3.0-fold (0.48 log units) above it; the measured number lies below the stated range.
By their numbers in this assay, from the lowest: compounds 3, 4 and 1 (each within the scatter of the next); then compound 2.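

In this assay, the change from amino to methyl on a sulfonyl sulfur can now be read directly: a 4.5-fold lower number from compound 2 to compound 4 (0.66 log units; beyond the scatter) is a modest step, beyond the scatter. On the core shared by these two compounds, sulfamoyl and methylsulfonyl are therefore not interchangeable, which compound 1 and compound 3 could not show, as they also differ elsewhere. Nothing shown here accounts for the step.

Within the data shown here, whether the step would hold on another core stays open, as this single pair is the only direct reading of the change. Also open, from the compounds shown here alone, is how other groups on the sulfonyl sulfur, such as an ethyl chain, a dimethylamino group or a cyclopropyl ring, would read in this assay.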